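Swapping the sulfonyl aryl group on a piperidine ketone series

This account rests on a few compounds, and the source may have more. Where it says the series, first, only, none or still open, it means among the compounds named here.

Of the compounds shown here, three sharing one core have been tested in an assay on HEK293 cells for displacement of a labelled ligand from 5-hydroxytryptamine receptor 6 (Homo sapiens), with a stated time of 60 min, tested at 0.01 uM, in the presence of a further agent that is not named here; a higher number here means a stronger effect of the compound at the concentration tested, a lower number a weaker effect. Compound 1 `COc1ccc(S(=O)(=O)N2CCC(CCC(=O)c3cc(Cl)c(N)cc3OC)CC2)cc1` gave "not active" (no number reported) there. Compound 2 `COc1ccc(S(=O)(=O)NCCN2CCC(CCC(=O)c3cc(Cl)c(N)cc3OC)CC2)cc1Br` likewise gave "not active" (no number reported) in this assay. Compound 3 `COc1ccc(S(=O)(=O)CCCN2CCC(CCC(=O)c3cc(Cl)c(N)cc3OC)CC2)cc1` gave 10% in this assay. Among the measured compounds shown here, compound 2 therefore stands among the compounds without a reported number: nothing sets it apart from compound 1, and the single number from compound 3 is itself small.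

The step now followed leads from compound 2 to compound 4 `COc1cc(N)c(Cl)cc1C(=O)CCC1CCN(CCNS(=O)(=O)c2ccc(NC(C)=O)cc2)CC1`, which has not yet been tested in this assay. The change is 4-acetamidophenyl in place of 3-bromo-4-methoxyphenyl on a sulfonyl sulfur; it places an acetamide on the aryl ring of the sulfonamide where a bromine and a methoxy group stood before. For the measured compounds named here, no measured pair shows such a change, so its size in this assay is not known from the data; given that compound 2 gave "not active" (no number reported) and compound 1 gave "not active" (no number reported), no step beyond the scatter in either direction is expected.

Compound 4 is therefore estimated to give 6% in this assay, expected to fall between 0% and 20%.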

Compound 4, a percentage reported as inhibition, at one concentration (the size of the read-out at that concentration, not a potency): 7%
Compound 4: the middle estimate sits 1 percentage points below what was measured; measured number inside the range.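

In this assay, among the compounds shown here, compound 4 gives 7% while compound 2 gives "not active" (no number reported) and so no step between the two can be read. The compounds shown leave open how 4-acetamidophenyl and 3-bromo-4-methoxyphenyl compare when placed on the sulfonyl sulfur. No information is available that would account for these results.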